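The source may hold more compounds than are shown below. What is called first, only, known or untested is meant among the compounds shown, and "the series" means these compounds.

Measured so far:
- compound 1 `[O-][n+]1nc(NC2CCC2)[n+]([O-])c2ccc(Cl)cc21`: 1.6 ug/mL
- compound 2 `COCC(C)Nc1n[n+]([O-])c2cc(Cl)ccc2[n+]1[O-]`: 2.6 ug/mL

Going by the values given here, in an ADME assay on Vero cells (Chlorocebus sabaeus) for cytotoxicity, read by CellTiter-Glo, with a stated time of 72 h (a higher number here means that more compound is tolerated, a lower number that less compound is tolerated), compound 2 stands level with compound 1, the only other measured compound: a 1.6-fold higher number from compound 1 to compound 2 (0.21 log units; within the scatter). Compound 3 `[O-][n+]1nc(N[C@@H]2C[C@H]3CC[C@@H]2C3)[n+]([O-])c2ccc(Cl)cc21` differs from compound 2 in one place: a group of 7 heavy atoms (7 carbon; 2 five-membered non-aromatic rings of carbon only) in place of a group of 5 heavy atoms (4 carbon, 1 oxygen; no ring), on a nitrogen on an aromatic ring. Among the compounds with values here, only one measured step bears on this change, the exchange of cyclobutyl for 1-(methoxymethyl)ethyl at the same nitrogen, and it stayed within the scatter. No step beyond the scatter is therefore expected in this assay, and no direction can be favoured. The estimate for compound 3 is 2 ug/mL, with an expected range from 0.8 ug/mL to 5 ug/mL. That would be an expected 1.3-fold lower number from compound 2 to compound 3 (0.11 log units; within the scatter).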

Compound 3, half-maximal cytotoxic concentration: 1.1 ug/mL
The estimate for compound 3 lay 1.8-fold (0.26 log units) above the measured number, and the stated range covers the measured number.
By their numbers in this assay, from the lowest: compounds 3, 1 and 2 (each within the scatter of the next, the first and the last beyond it).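

In this assay, going by these compounds alone, the position on the nitrogen now shows a first step beyond the scatter, though a modest one: a 2.4-fold lower number from compound 2 to compound 3 (0.37 log units; beyond the scatter), with the group of two five-membered non-aromatic rings of carbon only replacing 1-(methoxymethyl)ethyl. Set against cyclobutyl, the same group stays within the scatter, a 1.5-fold lower number from compound 1 to compound 3 (0.16 log units; within the scatter), so the two carbon-only ring groups are not separated here. Nothing available explains the step.

The compounds shown leave open how a chain bearing an amine or a carboxylic acid on this nitrogen would read in this assay. They also leave open whether the mirror-image form of the group in compound 3 would give the same number.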